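Taking the bromo group off compound 3

This account rests on a few compounds, and the source may have more. Where it says the series, first, only, none or still open, it means among the compounds named here.

In a physicochemical assay, with a stated time of 6 min (on this read-out higher numbers stand for weaker inhibition and lower numbers for stronger inhibition), so far:
compound 1 `COc1cccc(NC(=O)Nc2nc(-c3cc4ccccc4o3)cs2)c1` gives 200 nM
compound 2 `O=C(Nc1cccc(Cl)c1)Nc1nc(-c2cc3ccccc3o2)cs1` gives 14100 nM
compound 3 `O=C(Nc1nc(-c2cc3cc(Br)ccc3o2)cs1)Nc1ccccc1[N+](=O)[O-]` gives 166000 nM

Compound 3 has the highest number of the three, so it inhibits least. Compound 4 `O=C(Nc1nc(-c2cc3ccccc3o2)cs1)Nc1ccccc1[N+](=O)[O-]` is the same molecule with hydrogen in place of bromo on an aromatic carbon. For the measured compounds named here, no measured pair isolates this swap. Going by the values given here, the only measured step, a 71-fold higher number from compound 1 to compound 2 (1.85 log units; beyond the scatter), is large, but it is a chloro-for-methoxy swap elsewhere in the molecule. Among the compounds with values here, it shows only that one small swap can move the number a long way in this set. Compound 2, which has no bromo group, reads lower at 14100 nM, though it also differs from compound 3 in another group. A moderate step towards a lower number in this assay is therefore expected, with real uncertainty. The estimated step is a 3.3-fold lower number from compound 3 to compound 4 (0.52 log units; beyond the scatter) and could turn out to be larger or smaller. The expected value for compound 4 is 50000 nM, within an estimated range of 6000 nM to 250000 nM and no tighter.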

Compound 4, half-maximal inhibitory concentration: 20300 nM
Compound 4: the middle estimate sits 2.5-fold (0.39 log units) above what was measured; measured number inside the range.
By their numbers in this assay, from the lowest: compound 1; then compounds 2 and 4 (each within the scatter of the next); then compound 3.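

In this assay, for the compounds shown here, the pair isolates the bromo group on an aromatic carbon of the fused system for the first time: replacing it with hydrogen, with the 2-nitrophenyl group held fixed, gives a modest change (an 8.2-fold lower number from compound 3 to compound 4 (0.91 log units; beyond the scatter)). Without the bromo group, the aryl groups on the amide-type nitrogen can also be compared directly: 2-nitrophenyl in place of 3-chlorophenyl leaves the number within the scatter (a 1.4-fold higher number from compound 2 to compound 4 (0.16 log units; within the scatter)), whereas 2-nitrophenyl in place of 3-methoxyphenyl produces a large change (a 100-fold higher number from compound 1 to compound 4 (2.01 log units; beyond the scatter)). No measurement here explains the size of any of these steps.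

On these data alone, whether the bromo step would be similar with 3-methoxyphenyl or 3-chlorophenyl on that nitrogen remains open. So does how an amine or a methyl group at the bromo position would compare with bromo and hydrogen.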